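This account rests on a few compounds, and the source may have more. Where it says the series, first, only, none or still open, it means among the compounds named here.

Compound 1 `CN(C)CCNc1nc(-c2ccc(NC(=O)Nc3ccccc3Cl)cc2)nc2ccsc12` joins a shared core to a urea that ends in a 2-chlorophenyl group. In a functional assay on MKN-45 cells (Homo sapiens) for cytotoxicity, read by MTT assay, with a stated time of 72 h (on this read-out higher numbers stand for weaker inhibition and lower numbers for stronger inhibition), compound 1 gives 850 nM. Compound 2 `CN(C)CCNc1nc(-c2ccc(NC(=O)Nc3ccc(Cl)cc3Cl)cc2)nc2ccsc12` differs from compound 1 in one place: chloro in place of hydrogen on an aromatic carbon. This change gave a 2.8-fold higher number from compound 1 to compound 2 (0.44 log units; beyond the scatter), so that in this assay compound 2 gives 2360 nM.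

Compound 3 `CCN(CC)CCCNc1nc(-c2ccc(NC(=O)Nc3ccccc3Cl)cc2)nc2c(Cl)c(Cl)sc12` carries the same 2-chlorophenyl urea on another core; the difference between the two cores is not broken down here. In this assay compound 3 gives 1450 nM, a number that lies within the usual scatter of both compound 1 and compound 2, so these three values alone set no order among them.

Compound 4 `CCN(CC)CCCNc1nc(-c2ccc(NC(=O)Nc3ccc(Cl)cc3Cl)cc2)nc2c(Cl)c(Cl)sc12` stands to compound 3 as compound 2 stands to compound 1: chloro in place of hydrogen on an aromatic carbon. The place of the change is described in the same words for both pairs: on an aromatic carbon of a six-membered aromatic ring of carbon only, meta to a chloro group and para to a large group. Within these four compounds the change occurs twice, once measured and once not yet.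

Because the measured instance gave a 2.8-fold higher number from compound 1 to compound 2 (0.44 log units; beyond the scatter), a step of similar size is expected here: a 2.8-fold higher number from compound 3 to compound 4 (0.44 log units; beyond the scatter). A single measured example on a different core is thin ground, so the range is kept wide. For compound 4 in this assay a value near 4000 nM is estimated, between 1800 nM and 9000 nM.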

Compound 4, half-maximal inhibitory concentration: 5720 nM
Estimate against measurement, compound 4: 1.4-fold (0.16 log units) below, and the stated range covers the measured number.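

Placing a chloro group on the aromatic carbon, which turns the 2-chlorophenyl group into a 2,4-dichlorophenyl group, again raised the number in this assay, with a 3.9-fold higher number from compound 3 to compound 4 (0.60 log units; beyond the scatter) on this second core, so inhibition became weaker here as well. The two steps point the same way, and their sizes cannot be told apart: the same change on two cores in this assay, a 2.8-fold higher number (0.44 log units; beyond the scatter) from compound 1 to compound 2 and a 3.9-fold higher number (0.60 log units; beyond the scatter) from compound 3 to compound 4, 1.4-fold (0.15 log units) apart, within the scatter of two such steps. This shows that, within these two pairs, the effect of the change carried over from one core to the other, so the first step was a fair guide to the second; it does not show that the same would hold on any further core or in other cells, and two pairs cannot explain why the number rises.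

The compounds shown leave open whether a different group on the same aromatic carbon, such as fluoro, methyl or methoxy, would raise the number as chloro does, or would lower it instead. They also leave open how the step would behave with a cyclic amine such as morpholine or piperazine at the end of the side chain, and which of the differences between the two cores matters for the values.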